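Trimming the Aminomethyl Carbonyl Down to a Urea

This account rests on a few compounds, and the source may have more. Where it says the series, first, only, none or still open, it means among the compounds named here.

Compound 2 `NCC(=O)NC[C@@H]1CCCc2cc(S(=O)(=O)c3cccc(F)c3)ccc21` carries an (aminomethyl)carbonyl on the amine nitrogen of the shared core, and in an assay on isolated protein for displacement of a labelled ligand from 5-hydroxytryptamine receptor 6 (Homo sapiens) (a lower number here means a stronger inhibitor, a higher number a weaker inhibitor), compound 2 gives 0.316 nM. For the measured compounds named here, of the two numbers measured so far, that is the higher one; its only neighbour is compound 1 `O=C1CN=C(NC[C@@H]2CCCc3cc(S(=O)(=O)c4cccc(F)c4)ccc32)N1`, which in this assay gives 0.1 nM. Going by the values given here, the single measured step, a 3.2-fold higher number from compound 1 to compound 2 (0.50 log units; beyond the scatter), exchanged the ring-containing group on that nitrogen for the open-chain one and is the only comparison at hand.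

Compound 3 `NC(=O)NC[C@@H]1CCCc2cc(S(=O)(=O)c3cccc(F)c3)ccc21` differs from compound 2 by amino in place of aminomethyl on a carbonyl carbon, so that the ((aminomethyl)carbonyl)amino becomes ureido. Among the compounds with values here, no measured step covers this exact change; the only guide is a 3.2-fold higher number from compound 1 to compound 2 (0.50 log units; beyond the scatter), in which shrinking the group on that nitrogen raised the number modestly. Shrinking the same group once more is therefore expected to raise the number again by a modest step, a 3.2-fold higher number from compound 2 to compound 3 (0.50 log units; beyond the scatter), beyond the scatter but not large. Compound 3 is expected to give 1 nM in this assay, with a range from 0.3 nM to 4 nM.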

Compound 3, inhibition constant: 0.2 nM
Estimate against measurement, compound 3: 5.0-fold (0.70 log units) above; the measured number lies below the stated range.
By their numbers in this assay, from the lowest: compounds 1, 3 and 2 (each within the scatter of the next, the first and the last beyond it).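

Amino in place of aminomethyl on a carbonyl carbon, which turns the ((aminomethyl)carbonyl)amino into ureido, gives a step that stays inside the scatter in this assay (a 1.6-fold lower number from compound 2 to compound 3 (0.20 log units; within the scatter)), so this change does not separate compound 3 from compound 2. The ureido of compound 3 set against the ring-containing group of compound 1 on the amine nitrogen also stays inside the scatter (a 2.0-fold higher number from compound 1 to compound 3 (0.30 log units; within the scatter)), which leaves the earlier step (a 3.2-fold higher number from compound 1 to compound 2 (0.50 log units; beyond the scatter)) as the only one of the three beyond it, and shows that the ring-containing group is not needed for a number in this range at this position. Nothing measured here bears on why the numbers fall this way.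

The compounds shown leave open whether a longer chain such as aminoethyl on that carbonyl carbon, or a methyl or a hydroxyl in place of the amino, would keep the number in this range. They also leave open whether a methyl on the ureido nitrogens would be tolerated, and whether ureido would behave the same way on any other core.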